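A few compounds are considered here, and "the series" means these few. Any claim that something is new, unique, unknown or untested is made for them only; others in the source may bear on it.

In a physicochemical assay for lipophilicity, read by HPLC, in phosphate buffer, measured as chromatographic lipophilicity, at pH 7.4 (a higher number here means a more lipophilic compound, a lower number a more polar compound), compound 3 `COc1ccc2nc(C)cc(OCC(=O)Nc3cc(C)ccc3C)c2c1` gives 5.05, the lowest of the three numbers recorded. Compound 2 `COc1ccc2nc(C)cc(NC(=O)C(=O)Nc3cc(C)cc(C)c3)c2c1` gives 6.47 in this assay, a number beyond the scatter above compound 3, and compound 1 `Cc1cc(C)cc(NC(=O)COc2cc(C)nc3ccc(C(F)(F)F)cc23)c1` gives 6.67 in this assay, furthest from compound 3. Compound 4 `COc1ccc2nc(C)cc(OCC(=O)Nc3noc(C)c3C)c2c1` has not yet been measured. It differs from compound 3 in one place: 4,5-dimethyl-1,2-oxazol-3-yl in place of 2,5-dimethylphenyl on an amide-type nitrogen. For the measured compounds named here, no pair of measured compounds that differ in a single place is available, so the size of this step rests on the structures alone. In this assay the expected step is a number 1.15 log units lower from compound 3 to compound 4 (beyond the scatter), downward and beyond the scatter. Compound 4 is therefore estimated at 3.9, with a range from 3.2 to 4.6.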

Compound 4, distribution coefficient: 3.3
For compound 4 the middle estimate is 0.60 log units above the measured one; low and high end bracket the measured number.
By their numbers in this assay, from the lowest: compound 4; then compound 3; then compounds 2 and 1 (each within the scatter of the next).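

For the compounds shown here, this is the first single-place step, and in this assay replacing 2,5-dimethylphenyl with 4,5-dimethyl-1,2-oxazol-3-yl on an amide-type nitrogen gives a number 1.75 log units lower from compound 3 to compound 4 (beyond the scatter), which is large. The read-out therefore depends strongly on the group at this position, at least on the core shared by these two compounds. No measurement shown explains the size of this step.

As far as these compounds go, whether a similar step would appear on the core of compound 1 remains open. So does how a pyridine ring or an unsubstituted phenyl ring on this nitrogen would read.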